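This account rests on a few compounds, and the source may have more. Where it says the series, first, only, none or still open, it means among the compounds named here.

The measured compounds:
compound 1 `COc1cc2c(cc1CC=C(C)C)C(=O)C[C@@H](c1ccc(Oc3ccccc3)cc1)O2`, 69% in a functional assay on MCF7 cells (Homo sapiens) for inhibition, read by sulforhodamine B assay, with a stated time of 48 h, tested at 50 uM; a higher number here means more inhibition of growth at the concentration tested, a lower number less inhibition of growth;
compound 2 `COc1ccc([C@@H]2C/C(=N/OCc3cn(-c4ccc(C#N)cc4)nn3)c3cc(CC=C(C)C)c(OC)cc3O2)cc1`, 40%;
compound 3 `COc1ccc([C@@H]2C/C(=N/OCc3cn(-c4ccc(NC(=O)c5ccccc5)cc4)nn3)c3cc(CC=C(C)C)c(OC)cc3O2)cc1`, 4%.

Compound 1 stands highest of the three numbers in this assay; compound 2 lies nearest, a step beyond the scatter below it, and compound 3 furthest. For the measured compounds named here, the only step measured, a number 36 percentage points lower from compound 2 to compound 3 (beyond the scatter), concerns benzamido in place of cyano on an aromatic carbon and says nothing about the oxygen on the aromatic ring where compound 4 `CCCCOc1ccc([C@@H]2CC(=O)c3cc(CC=C(C)C)c(OC)cc3O2)cc1` differs from compound 1: butyl in place of phenyl on an oxygen on an aromatic ring. Going by the values given here, no measured step bears on this change, so its size and direction remain open. The account therefore expects a step of a number 14 percentage points lower from compound 1 to compound 4 (beyond the scatter), quite possibly within the scatter. Compound 4 is estimated at 55%, between 30% and 80%.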

Compound 4, percent growth inhibition at one concentration: 57%
Estimate against measurement, compound 4: 2 percentage points below, and the stated range covers the measured number.
By their numbers in this assay, from the lowest: compound 3; then compound 2; then compound 4; then compound 1.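

With butyl in place of phenyl on an oxygen on an aromatic ring, this assay shows a number 12 percentage points lower from compound 1 to compound 4 (beyond the scatter) as a modest step. This position therefore accepts an open chain as well as an aromatic ring, and compound 4 keeps 57% in this read-out while phenoxy remains the better of the two groups. Nothing measured here explains the step.

The compounds shown leave open how a longer chain, a benzyl group or a chain ending in an amine would read on this oxygen. They also leave open whether the phenoxy to butoxy step would keep its size and direction on a core other than that of compound 1.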